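A few compounds are considered here, and "the series" means these few. Any claim that something is new, unique, unknown or untested is made for them only; others in the source may bear on it.

Of the compounds shown here, three have so far been tested in an assay on HEK293 cells for displacement of a labelled ligand from 5-hydroxytryptamine receptor 6 (Homo sapiens), read by radioligand binding, with a stated time of 60 min, tested at 100 nM; a higher number here means more inhibition at the concentration tested (going by the name of the read-out), a lower number less inhibition. Compound 1 `CN(c1cccc2ccccc12)S(=O)(=O)c1ccc2c(c1)sc(=O)n2CCN1CCCCC1` gives 14% in this assay. Compound 2 `O=c1sc2cc(S(=O)(=O)Nc3ccccc3)ccc2n1CCN1CCCCC1` gives 7%, and compound 3 `O=c1sc2cc(S(=O)(=O)Nc3cccc4ccccc34)ccc2n1CCN1CCCC1` gives 0%. On these numbers compound 3 holds the smallest value of the three, but compound 2 lies within the usual scatter of it, so the two cannot be told apart; only compound 1 stands beyond the scatter above compound 3.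

Compound 4 `O=c1sc2cc(S(=O)(=O)Nc3cccc4ccccc34)ccc2n1CCN1CCCCC1` is the next compound to be measured. It differs from compound 3 in one place: piperidin-1-yl in place of pyrrolidin-1-yl on a saturated chain carbon, two bonds along the chain from an aromatic nitrogen. Within the data shown here, no measured pair shows this single change on its own, so no direct step for it can be read from the data. Compound 1 does carry the piperidin-1-yl ring, yet it also differs from compound 3 elsewhere, so its value cannot be credited to the ring alone. In this assay the step of a number 8 percentage points higher from compound 3 to compound 4 (within the scatter) is expected to stay within the scatter. Compound 4 is therefore estimated to give 8%, with a range from 0% to 22%.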

Compound 4, a percentage reported as inhibition, at one concentration (the size of the read-out at that concentration, not a potency): 3%
Compound 4: the middle estimate sits 5 percentage points above what was measured; low and high end bracket the measured number.
By their numbers in this assay, from the lowest: compounds 3, 4, 2 and 1 (each within the scatter of the next, the first and the last beyond it).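

With the ring on a saturated chain carbon, two bonds along the chain from an aromatic nitrogen, piperidin-1-yl in place of pyrrolidin-1-yl gives a number 3 percentage points higher from compound 3 to compound 4 (within the scatter) in this assay, so the two rings cannot be told apart in this measurement. Naphthalen-1-yl in place of phenyl on the sulfonamide nitrogen likewise gives a number 4 percentage points lower from compound 2 to compound 4 (within the scatter), while hydrogen in place of methyl on that nitrogen gives a number 11 percentage points lower from compound 1 to compound 4 (beyond the scatter), making the sulfonamide nitrogen the only one of these three places where a single change moves the number beyond the scatter. Nothing available explains this step.

As far as these compounds go, it remains open whether a larger group on the sulfonamide nitrogen, such as ethyl, would carry the step further. From the compounds shown here alone, it is also open whether a morpholin-4-yl ring or a longer chain, such as 3-(piperidin-1-yl)propyl, would change the reading.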